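The compounds below may be only part of what the source reports. "The series", "measured", "known", "first", "only" and "open" are said of these compounds alone.

Compound 1 `Fc1ccc(CN2CCC(NCCSC(c3ccc(F)cc3)c3ccc(F)cc3)CC2)cc1` is the starting point of this series. In an assay on membranes from Cortex for displacement of a labelled ligand from Sigma non-opioid intracellular receptor 1 (Cavia porcellus), read by scintillation counting, with a stated time of 120 min (on this read-out higher numbers stand for weaker inhibition and lower numbers for stronger inhibition), compound 1 gives 13.3 nM. Compound 2 `Fc1ccc(C(SCCNC2CCN(Cc3ccc(C(F)(F)F)cc3)CC2)c2ccc(F)cc2)cc1` keeps the same shared core, and in this assay compound 2 gives 186 nM; the change of a 14-fold higher number from compound 1 to compound 2 (1.15 log units; beyond the scatter) came with trifluoromethyl in place of fluoro on an aromatic carbon. Compound 3 `[O-][S+](CCNC1CCN(Cc2ccc(F)cc2)CC1)C(c1ccc(F)cc1)c1ccc(F)cc1` gives 26.5 nM in this assay. Among the three measured compounds, compound 2 stands at the highest number, so it is the weakest binder here, with compound 3 nearer to it than compound 1.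

Compound 4 `O=C(c1cc2ccccc2o1)N1CCC(NCCSC(c2ccc(F)cc2)c2ccc(F)cc2)CC1` has not yet been measured. Relative to compound 2 the change is (1-benzofuran-2-yl)carbonyl in place of 4-(trifluoromethyl)benzyl on an amine nitrogen in a ring. For the measured compounds named here, the only measured step, from compound 1 to compound 2, concerns a substituent on the benzyl ring and not the exchange of the whole benzyl group for an acyl group, so it offers no direct precedent. It is estimated that compound 4 will give 60 nM, with a range from 10 nM to 400 nM. This estimate means a step of a 3.1-fold lower number from compound 2 to compound 4 (0.49 log units; beyond the scatter) is expected, downward, but with wide uncertainty.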

Compound 4, inhibition constant: 304 nM
Compound 4: the middle estimate sits 5.1-fold (0.70 log units) below what was measured; measured number inside the range.
By their numbers in this assay, from the lowest: compounds 1 and 3 (each within the scatter of the next); then compounds 2 and 4 (each within the scatter of the next).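

At the amine nitrogen in the ring, a whole-group exchange now joins the earlier change on the benzyl ring. In this assay, replacing 4-(trifluoromethyl)benzyl with (1-benzofuran-2-yl)carbonyl gives a 1.6-fold higher number from compound 2 to compound 4 (0.21 log units; within the scatter), so these two different groups cannot be told apart on this read-out. Replacing 4-fluorobenzyl with the same group gives a 23-fold higher number from compound 1 to compound 4 (1.36 log units; beyond the scatter), which shows that the low number of compound 1 does not survive this exchange. (Nothing measured here explains either step)

The compounds shown leave open whether the carbonyl or the benzofuran ring accounts for the large step from compound 1, and a (1-benzofuran-2-yl)methyl group on the same nitrogen would separate the two. An unsubstituted benzyl group would show how much the fluoro and trifluoromethyl substituents each contribute.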